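A few compounds are considered here, and "the series" means these few. Any claim that something is new, unique, unknown or untested is made for them only; others in the source may bear on it.

Measured in a functional assay on SK-MEL-5 cells (Homo sapiens) for inhibition, read by sulforhodamine B assay, with a stated time of 48 h; on this read-out higher numbers stand for lower toxicity in this test and lower numbers for higher toxicity in this test:
Compound 1 `Nc1cc(N)c2nc(-c3ccccc3)c(NCc3ccc(Cl)c(Cl)c3)nc2c1` gives 34700 nM.
Compound 2 `COc1ccc(CNc2nc3cc(N)cc(N)c3nc2-c2ccccc2)cc1OC` gives 77600 nM.
Compound 3 `Nc1cc(N)c2nc(-c3ccccc3)c(NCc3ccc(F)cc3)nc2c1` gives 6920 nM.

Compound 3 stands lowest of the three in this assay, and both of its gaps to the other two numbers lie beyond the scatter. Compound 4 `COc1ccc(CNc2nc3cc(N)cc(N)c3nc2-c2ccccc2)cc1` differs from compound 3 by methoxy in place of fluoro on an aromatic carbon, that is 4-fluorobenzyl to 4-methoxybenzyl. The measured steps bearing on it are an 11-fold lower number from compound 2 to compound 3 (1.05 log units; beyond the scatter) and a 5.0-fold lower number from compound 1 to compound 3 (0.70 log units; beyond the scatter): moving away from the 4-fluorophenyl raised the number in both cases, and the methoxy-bearing compound 2 sits highest. A modest upward step is therefore expected, a 2.9-fold higher number from compound 3 to compound 4 (0.46 log units; beyond the scatter), smaller than the dimethoxy case since only one methoxy enters. Compound 4 is estimated at 20000 nM, range 7000 nM to 60000 nM.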

Compound 4, concentration lethal to 50% of the cells: 56200 nM
Estimate against measurement, compound 4: 2.8-fold (0.45 log units) below; low and high end bracket the measured number.
By their numbers in this assay, from the lowest: compound 3; then compounds 1, 4 and 2 (each within the scatter of the next, the first and the last beyond it).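

In this assay a single methoxy in place of fluoro at this para position is enough to leave the low number of compound 3 (an 8.1-fold higher number from compound 3 to compound 4 (0.91 log units; beyond the scatter)). The added methoxy of the 3,4-dimethoxyphenyl changes nothing readable (a 1.4-fold lower number from compound 2 to compound 4 (0.14 log units; within the scatter)), and the 3,4-dichlorophenyl likewise stays within the scatter (a 1.6-fold higher number from compound 1 to compound 4 (0.21 log units; within the scatter)). Among these four compounds, only the 4-fluorobenzyl of compound 3 stands apart.

Open, going by these compounds, is whether a plain benzyl, or an amine or carboxylic acid on that aromatic carbon, would side with compound 3 or the other three. Nothing available explains the difference between fluoro and methoxy here.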